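Amide ring change from compound 2 to compound 4

This account rests on a few compounds, and the source may have more. Where it says the series, first, only, none or still open, it means among the compounds named here.

In a physicochemical assay for solubility, read by nephelometry, measured as kinetic solubility, at pH 2.0 (a lower number here means a less soluble compound, a higher number a more soluble compound), the compounds give the following:
compound 1 `NCc1csc(NC(=O)c2ccccn2)n1` gives > 100 ug/mL as a limit
compound 2 `NCc1csc(NC(=O)c2ccon2)n1` gives 50 ug/mL as a number
compound 3 `NCc1csc(NC(=O)c2cnnn2Cc2ccccc2)n1` gives > 100 ug/mL as a limit

In this assay, among the compounds with values here, compound 2 gives 50 ug/mL and is the only compound here with a number. The other results offer only the limit of > 100 ug/mL in this assay, at which 2 of the 3 values shown sit, and no number.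

Compound 4 `NCc1csc(NC(=O)c2ccn[nH]2)n1` keeps the shared core and differs from compound 2 as follows: 1H-pyrazol-5-yl in place of 1,2-oxazol-3-yl on a carbonyl carbon and so carries 1H-pyrazol-5-yl in place of 1,2-oxazol-3-yl on a carbonyl carbon.

Within the data shown here, no measured pair shows this change, so any step remains a judgement. Compound 2 at 50 ug/mL serves as the anchor. Compound 1 and compound 3 are both reported as limits, and a small rise is expected. The expectation is a 1.4-fold higher number from compound 2 to compound 4 (0.15 log units; within the scatter) and this stays within the usual scatter. A limit rather than a number is also possible for compound 4. For compound 4 the estimate is 70 ug/mL in an expected range from 35 ug/mL to 120 ug/mL when it is measured.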

Compound 4, solubility: > 100 ug/mL
Compound 4: only a limit was reported; the forecaster's own chance of this, stated with the estimate: 30%; middle value at least 1.4-fold (0.15 log units) from the limit.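

In this assay, the position on a carbonyl carbon now has its first readable step, an at least 2.0-fold higher number from compound 2 to compound 4 (0.30 log units; that floor lies within the scatter), for 1H-pyrazol-5-yl in place of 1,2-oxazol-3-yl. The exchange keeps five heavy atoms and a five-membered aromatic ring with two hetero atoms, while the counts move from no hydrogen-bond donor and two acceptors to one donor and one acceptor. Compound 4 is reported only as a limit, and the size of the step cannot be read further, because the result stands at the ceiling of the read-out: the limit of > 100 ug/mL in this assay, at which 3 of the 4 values shown sit.

The floor of the step lies within the usual scatter, so the compounds shown do not establish a real separation between the two rings, and they do not separate any contribution of the added donor from that of the lost ring oxygen. A methyl group in place of the hydrogen on the nitrogen of 1H-pyrazol-5-yl would test the donor alone, but only if the compound gave a number rather than a limit in this assay.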